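Fluoro for Methyl on the Benzoyl Ring

The compounds below may be only part of what the source reports. "The series", "measured", "known", "first", "only" and "open" are said of these compounds alone.

Measured compounds:
compound 1 `Cc1ccc(C(=O)c2ccc(OCC(=O)Nc3nc(-c4ccccc4)cs3)c(C)c2)cc1` — 29900 nM
compound 2 `COc1ccc(-c2csc(NC(=O)COc3ccc(C(=O)c4ccc(C)cc4)cc3C)n2)cc1` — 20700 nM

In a functional assay on Ehrlich cells (Mus musculus) for cytotoxicity, read by MTT assay, with a stated time of 48 h (on this read-out lower numbers stand for stronger inhibition and higher numbers for weaker inhibition), compound 2 gives 20700 nM, the lowest of the two numbers in hand. Compound 1 gives 29900 nM. Among the compounds with values here, the only measured step, a 1.4-fold lower number from compound 1 to compound 2 (0.16 log units; within the scatter), lies within the scatter, so the two compounds cannot be set in order on this read-out.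

Compound 3 `COc1ccc(-c2csc(NC(=O)COc3ccc(C(=O)c4ccc(F)cc4)cc3C)n2)cc1` differs from compound 2 by fluoro in place of methyl on an aromatic carbon. Within the data shown here, no measured step touches that ring or that exchange; the one step that exists concerns a methoxy on a different ring and was within the scatter, so it gives no direction for the present change. With nothing in the data pointing up or down, the expected step in this assay is a 1.1-fold higher number from compound 2 to compound 3 (0.03 log units; within the scatter), none beyond the scatter. Compound 3 is therefore estimated at 22000 nM, with a range from 9000 nM to 55000 nM.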

Compound 3, half-maximal inhibitory concentration: 5400 nM
Compound 3: middle estimate off by 4.1-fold (0.61 log units), on the high side; the whole stated range lies above it.
By their numbers in this assay, from the lowest: compound 3; then compounds 2 and 1 (each within the scatter of the next).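

In this assay, within the data shown here, the exchange of 4-methylphenyl for 4-fluorophenyl gives a 3.8-fold lower number from compound 2 to compound 3 (0.58 log units; beyond the scatter), the only step in the set so far that lies beyond the scatter. This position, para to a large group, therefore responds to a one-atom change, which the earlier methoxy step on the other ring could not show. The material at hand offers no measurement that accounts for this step.

The compounds shown leave open whether the lower number follows from the arrival of fluoro or from the departure of methyl, a question that hydrogen, chloro or a nitrile at the same place would help to settle. They also leave open whether the same exchange would have a similar size on the core of compound 1, which lacks the methoxy.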